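Fluorophenyl positional swap on a triazole series: cytotoxicity outlook

A few compounds are considered here, and "the series" means these few. Any claim that something is new, unique, unknown or untested is made for them only; others in the source may bear on it.

Measured compounds:
compound 1 `CCCCCc1cn(C(c2ccccc2)c2cc3cc(Br)ccc3nc2OC)nn1`: -2%
compound 2 `COc1nc2ccc(Br)cc2cc1C(c1ccccc1)n1cc(-c2ccc(OC(F)(F)F)cc2)nn1`: 5.8%
compound 3 `COc1nc2ccc(Br)cc2cc1C(c1ccccc1)n1cc(-c2cccc(F)c2)nn1`: 6.84%

In an ADME assay on HEK293 cells (Homo sapiens) for cytotoxicity, read by sulforhodamine B assay, with a stated time of 48 h, tested at 10 uM (on this read-out lower numbers stand for less inhibition and higher numbers for more inhibition at the one concentration tested (going by the name of the read-out)), compound 3 gives 6.84%, the highest of the three numbers, yet its gaps to compound 2 and to compound 1 both sit within the scatter, so no order among them can be read. Compound 4 `COc1nc2ccc(Br)cc2cc1C(c1ccccc1)n1cc(-c2ccc(F)cc2)nn1` differs from compound 3 by 4-fluorophenyl in place of 3-fluorophenyl on an aromatic carbon. The step that bears on it is the earlier aryl swap, a number 1 percentage points higher from compound 2 to compound 3 (within the scatter), and the two steps from compound 1, a number 7.8 percentage points higher from compound 1 to compound 2 (within the scatter) and a number 8.8 percentage points higher from compound 1 to compound 3 (within the scatter), also stayed within the scatter. The step of a number 1.8 percentage points lower from compound 3 to compound 4 (within the scatter) is therefore expected to be none beyond the scatter. Compound 4 is estimated at 5%, ranging from -5% to 15%.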

Compound 4, a percentage reported as inhibition, at one concentration (the size of the read-out at that concentration, not a potency): 4.04%
Compound 4: the middle estimate sits 1 percentage points above what was measured; the measured number falls inside the stated range.
By their numbers in this assay, from the lowest: compounds 1, 4, 2 and 3 (each within the scatter of the next).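

In this assay, for the compounds shown here, 4-fluorophenyl in place of 3-fluorophenyl gives a number 2.8 percentage points lower from compound 3 to compound 4 (within the scatter), so this pair offers the first look at where the fluorine sits on the phenyl, and the two isomers are not separated. Fluoro in place of trifluoromethoxy gives a number 1.8 percentage points lower from compound 2 to compound 4 (within the scatter), and 4-fluorophenyl in place of pentyl gives a number 6 percentage points higher from compound 1 to compound 4 (within the scatter), so all four groups on this aromatic carbon read alike. Nothing available here accounts for these numbers. Going by these compounds, whether an amine, a carboxylic acid or a longer chain at this carbon would stay within the scatter remains open.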